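Methoxy to fluoro on the aryl substituent

The compounds below may be only part of what the source reports. "The series", "measured", "known", "first", "only" and "open" are said of these compounds alone.

Measured compounds:
compound 1 `N#Cc1c(-c2ccco2)nc2c(c(-c3ccccc3)nn2-c2ccccc2)c1-c1ccc(O)cc1` 10000 nM
compound 2 `COc1ccc(-c2nc3c(c(-c4ccccc4)nn3-c3ccccc3)c(-c3ccc(O)cc3)c2C#N)cc1` 200 nM

In a functional assay on KOPN-8 cells (Homo sapiens) for antiproliferative activity, read by resazurin assay, with a stated time of 72 h (a lower number here means a stronger inhibitor, a higher number a weaker inhibitor), compound 2 gives the lowest of the two numbers; the step of a 50-fold lower number from compound 1 to compound 2 (1.70 log units; beyond the scatter) is large and beyond the scatter. Compound 3 `N#Cc1c(-c2ccc(F)cc2)nc2c(c(-c3ccccc3)nn2-c2ccccc2)c1-c1ccc(O)cc1` differs from compound 2 by fluoro in place of methoxy on an aromatic carbon. For the measured compounds named here, no measured step addresses methoxy against fluoro on this ring; the only step, a 50-fold lower number from compound 1 to compound 2 (1.70 log units; beyond the scatter), shows that exchanging the whole aryl group moves this assay strongly, whereas compound 3 keeps the phenyl ring. A modest weakening is therefore expected, a 2.5-fold higher number from compound 2 to compound 3 (0.40 log units; beyond the scatter). Compound 3 is estimated at 500 nM, within 100 nM to 3000 nM.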

Compound 3, half-maximal inhibitory concentration: 1300 nM
For compound 3 the middle estimate is 2.6-fold (0.41 log units) below the measured one; measured number inside the range.
By their numbers in this assay, from the lowest: compound 2; then compound 3; then compound 1.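

In this assay the substituent on the retained phenyl ring matters on its own: with the ring kept, fluoro in place of methoxy gives (a 6.5-fold higher number from compound 2 to compound 3 (0.81 log units; beyond the scatter)). Replacing furan-2-yl with 4-fluorophenyl still gives (a 7.7-fold lower number from compound 1 to compound 3 (0.89 log units; beyond the scatter)), so an aryl change without methoxy also improves on compound 1, though compound 2 keeps the lowest number. No supporting measurement accounts for either step. Still open, from the compounds shown here alone, is how an amine, a hydroxyl or a longer alkoxy chain on this ring would compare with methoxy and fluoro.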